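The source may hold more compounds than are shown below. What is called first, only, known or untested is meant among the compounds shown, and "the series" means these compounds.

Compound 1, `CCCn1cnc2ncnc(N)c21`. In an assay on CHO cells for displacement of a labelled ligand from adenosine receptor A1 (Homo sapiens) (a lower number here means a stronger inhibitor, a higher number a weaker inhibitor), compound 1 reaches only > 100000 nM, which is a limit of the assay rather than a number.
Compound 2, `CC(C)n1cnc2c(N)ncnc21`. In this assay compound 2 gives 4300 nM.
Compound 3, `CC(C)n1cnc2ncnc(N)c21`. In this assay compound 3 gives 20000 nM.

Compound 3 therefore stands with the higher of the two real numbers; compound 2, the nearest measured compound, sits lower by a gap that is beyond the scatter. Compound 4, `CC(C)Cn1cnc2ncnc(N)c21`, has not yet been measured. It differs from compound 3 in one place: isobutyl in place of isopropyl on an aromatic nitrogen. Among the measured compounds shown here, the only measured step on the same aromatic nitrogen is an at least 5.0-fold lower number from compound 1 to compound 3 (0.69 log units; beyond the scatter), which compared isopropyl with propyl. Isobutyl keeps a branch but carries one more carbon than isopropyl, so that step does not cover it directly; the data give no measured cause for either outcome. A change of at most modest size is expected, most likely toward a higher number. Compound 4 is expected to give about 30000 nM, between 8000 nM and 100000 nM, an estimated step of a 1.5-fold higher number from compound 3 to compound 4 (0.18 log units; within the scatter).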

Compound 4, inhibition constant: > 100000 nM
Compound 4 was reported as a limit; the forecaster's own chance of this, stated with the estimate: 25%; middle value at least 3.3-fold (0.52 log units) from the limit.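

Isobutyl in place of isopropyl gives an at least 5.0-fold higher number from compound 3 to compound 4 (0.69 log units; beyond the scatter) and so shows that keeping a branch is not enough on this aromatic nitrogen. The earlier compounds shown here showed only that the unbranched propyl of compound 1 fared worse than isopropyl, whereas the result now shows that one more carbon on the branched chain also moves the number up. Among the three chains tried here, isopropyl alone gives a real number in this assay and compound 1 and compound 4 cannot be compared with each other, because each is reported only as a limit: the limit of > 100000 nM in this assay, at which 2 of the 4 values shown sit.

As far as these compounds go, whether a smaller group such as ethyl or methyl, a ring such as cyclopropyl, or a chain carrying a hydroxyl group would do better on this nitrogen stays open. Also open, from the compounds shown here alone, is whether the core of compound 2 would respond to isobutyl in the same way.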